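Phenyl in Place of Hydrogen: Compound 3 to Compound 4

A few compounds are considered here, and "the series" means these few. Any claim that something is new, unique, unknown or untested is made for them only; others in the source may bear on it.

Of the compounds shown here, three have been measured in a functional assay for antagonist activity at Alpha-1A adrenergic receptor (Oryctolagus cuniculus); a higher number here means weaker binding, a lower number tighter binding. Compound 1 `COc1ccccc1N1CCN(CCCNc2ccc(C(=O)N(C)C)cn2)CC1` gives 25.1 nM, compound 2 `COc1ccccc1N1CCN(CCCOc2ccccc2C(=O)N(C)C)CC1` gives 3.98 nM, and compound 3 `CN(C)C(=O)c1cccnc1NCCCN1CCN(c2ccccc2)CC1` gives 6.31 nM. Compound 3 thus holds the second highest of the three numbers; its nearest neighbour is compound 2, a gap within the usual scatter, while compound 1 lies furthest away, beyond the scatter. Compound 4 `CN(C)C(=O)c1cccnc1NCCCN1CCN(c2ccccc2-c2ccccc2)CC1` differs from compound 3 by a single change: phenyl in place of hydrogen on an aromatic carbon. Among the measured compounds shown here, no measured pair shows this change, so its effect cannot be read from the data. A modest move toward a higher number in this assay is expected, and the expected step is a 1.6-fold higher number from compound 3 to compound 4 (0.20 log units; within the scatter). Compound 4 is therefore estimated at 10 nM, within a range from 3 nM to 40 nM.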

Compound 4, dissociation constant: 1.26 nM
Estimate against measurement, compound 4: 7.9-fold (0.90 log units) above; measured number below the stated range.
By their numbers in this assay, from the lowest: compound 4; then compounds 2 and 3 (each within the scatter of the next); then compound 1.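

In this assay, phenyl in place of hydrogen on an aromatic carbon, ortho to a large group, gives a 5.0-fold lower number from compound 3 to compound 4 (0.70 log units; beyond the scatter), so this position tolerates an added aromatic ring and the number falls. Among the compounds shown here, this is the first one-place step measured in the set, and it lies beyond the scatter. Nothing measured here explains the drop. Going by these compounds, whether it requires a full ring stays open: a methyl or methoxy group at this place would test that. On these data alone, how phenyl behaves on the ring's other carbons also remains unknown.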